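This account rests on a few compounds, and the source may have more. Where it says the series, first, only, none or still open, it means among the compounds named here.

Two amides built on the same core have been tested for how strongly they block the aldosterone-forming enzyme. The read-out is an assay on V79 cells for inhibition of cytochrome P450 11B2, mitochondrial (Homo sapiens); on this read-out lower numbers stand for stronger inhibition and higher numbers for weaker inhibition. Compound 1, with the structure `O=C(Nc1cccnc1)c1ccc(Cl)cc1`, gives 65 nM in this assay. Compound 2, with the structure `O=C(Nc1cccnc1)c1ccc(F)c(F)c1`, gives 53.5 nM in this assay. The two numbers lie within the usual scatter of each other, so the data show no real separation between compound 1 and compound 2; they only show that both sit in the same range.

Compound 3, with the structure `O=C(Nc1cccnc1)c1cc(F)c(F)cc1F`, has not been measured yet. It differs from compound 2 in one place: fluoro in place of hydrogen on an aromatic carbon. Among the measured compounds shown here, no step between two measured compounds tells what such a change does here, and the two measured values give no hint of a large swing in either direction. The expectation is therefore a small step from compound 2 to compound 3 in this assay, a 1.3-fold lower number from compound 2 to compound 3 (0.13 log units; within the scatter), not clearly beyond the scatter. Compound 3 is estimated at 40 nM, with a likely range from 15 nM to 110 nM.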

Compound 3, half-maximal inhibitory concentration: 166 nM
Beside the measured number, compound 3's estimate is 4.2-fold (0.62 log units) below it, and the stated range ends below it.
By their numbers in this assay, from the lowest: compounds 2 and 1 (each within the scatter of the next); then compound 3.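

In this assay fluoro in place of hydrogen on this aromatic carbon gives a 3.1-fold higher number from compound 2 to compound 3 (0.49 log units; beyond the scatter) and so a weaker inhibitor, which shows that this spot, ortho to a group of 9 heavy atoms, meta to one fluoro group and para to another, does respond to substitution. Among the compounds shown here, the earlier values could not show this: they sat within the scatter of each other, and no step between measured compounds existed, so this is the first sign that adding a single heavy atom to this ring can move the number beyond the scatter. The data at hand offer no measurement that explains why the step goes in this direction.

A single step at a single position leaves open whether the weakening belongs to fluoro in particular or would also appear with another group on the same carbon, such as methyl, methoxy or an amine. It also leaves open whether the same change would have a similar effect on a ring without the other two fluoro groups, where the surroundings of this carbon would be different.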